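The compounds below may be only part of what the source reports. "The series", "measured", "known", "first", "only" and "open" are said of these compounds alone.

Measured so far in a functional assay on A549 cells (Homo sapiens) for antiproliferative activity, tested at 1 uM; a higher number here means more inhibition at the concentration tested (going by the name of the read-out), a lower number less inhibition:
- compound 1 `Cc1nn(C)c(Oc2ccccc2)c1/C=N/OCc1ccc(C(F)(F)F)cc1`: 34.7%
- compound 2 `Cc1nn(C)c(Oc2ccc(Cl)cc2)c1/C=N/OCc1ccc([N+](=O)[O-])cc1`: 39.6%
- compound 3 `COc1cccc(CO/N=C/c2c(C)nn(C)c2Oc2ccccc2)c1`: 1%

Compound 3 stands lowest of the three numbers. Its nearest neighbour is compound 1, which sits well above it, beyond the scatter; compound 2 sits further above, also beyond the scatter. Compound 1 and compound 2 lie within the scatter of each other, so nothing is said about their order.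

Among the compounds with values here, no step between measured compounds that differ in one place is available, so the size of the change from compound 3 to compound 4 is judged from the values alone.

Compound 4 `Cc1nn(C)c(Oc2ccccc2)c1/C=N/OCc1ccc([N+](=O)[O-])cc1` is not yet measured. Relative to compound 3 it differs as follows: 4-nitrophenyl in place of 3-methoxyphenyl on a saturated chain carbon bound to an oxygen on an unsaturated carbon. The shared core and the phenyl ether of compound 3 are retained.

A step upward beyond the scatter is expected in this assay, since compound 2, which carries the same 4-nitrophenyl group, gives 39.6% and compound 4 shares the phenyl ether of compound 1, which gives 34.7%. Compound 4 is therefore estimated at 35%, with a range from 12% to 55%. The expected step is a number 34 percentage points higher from compound 3 to compound 4 (beyond the scatter). Within the data shown here, with only three numbers, the range is kept wide.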

Compound 4, a percentage reported as inhibition, at one concentration (the size of the read-out at that concentration, not a potency): 39.4%
Compound 4: the middle estimate sits 4.4 percentage points below what was measured; measured number inside the range.
By their numbers in this assay, from the lowest: compound 3; then compounds 1, 4 and 2 (each within the scatter of the next).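

In this assay, within the data shown here, the group on a saturated chain carbon bound to an oxygen on an unsaturated carbon decides the outcome for this pair: 4-nitrophenyl in place of 3-methoxyphenyl gives a number 38.4 percentage points higher from compound 3 to compound 4 (beyond the scatter), the only large single-place step in the set. That position does not respond to every change, however, since nitro in place of trifluoromethyl on an aromatic carbon gives a number 4.7 percentage points higher from compound 1 to compound 4 (within the scatter), leaving compound 1 and compound 4 not told apart and the low number confined to compound 3 among the compounds shown. On the phenyl ether, hydrogen in place of chloro on an aromatic carbon gives a number 0.2 percentage points lower from compound 2 to compound 4 (within the scatter), so this change has no readable effect in this read-out at the one concentration tested.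

No measurement shown gives a reason for the low number of compound 3. Still open, going by these compounds, is whether the methoxy group itself or its place on the ring goes with that low number, and whether an amine or a carboxylic acid in place of nitro would hold the level of compound 4 at 39.4%.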